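Chloro to acetyl at the edge of activity

A few compounds are considered here, and "the series" means these few. Any claim that something is new, unique, unknown or untested is made for them only; others in the source may bear on it.

In a functional assay on HepG2 cells (Homo sapiens) for antiproliferative activity, read by MTT assay (on this read-out lower numbers stand for stronger inhibition and higher numbers for weaker inhibition), compound 1 (`CC1(C)CCc2cc(C(=O)/C=C/c3ccc(OCc4cn(-c5ccc(Br)cc5)nn4)cc3)c(O)cc2O1`) is reported as "not active" (no number reported) and compound 2 (`CC(=O)c1ccc(-n2cc(COc3ccc(/C=C/C(=O)c4cc5c(cc4O)OC(C)(C)CC5)cc3)nn2)cc1`) as "not active" (no number reported) with no number given. Going by the values given here, compound 3 (`CC1(C)CCc2c(ccc(C(=O)/C=C/c3ccc(OCc4cn(-c5ccc(Cl)cc5)nn4)cc3)c2O)O1`) gives 102000 nM as the only number available. Compound 4 (`CC(=O)c1ccc(-n2cc(COc3ccc(/C=C/C(=O)c4ccc5c(c4O)CCC(C)(C)O5)cc3)nn2)cc1`) keeps the core of compound 3. The change is acetyl in place of chloro on an aromatic carbon. Compound 2 bears the same 4-acetylphenyl on a different core and reads "not active" (no number reported) with no sign of a gain. The expected 1.0-fold lower number from compound 3 to compound 4 (0.01 log units; within the scatter) stays within the usual scatter, although a report without a number is also possible. Compound 4 is estimated between 40000 nM and 250000 nM with 100000 nM as the middle value.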

Compound 4, half-maximal inhibitory concentration: 91400 nM
Beside the measured number, compound 4's estimate is 1.1-fold (0.04 log units) above it; the range from low to high includes it.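

In this assay, going by these compounds alone, the exchange of 4-chlorophenyl for 4-acetylphenyl gives a 1.1-fold lower number from compound 3 to compound 4 (0.05 log units; within the scatter), the only step that can be read here. On this core, the two groups cannot be told apart at this place, para to a large group, even though acetyl adds heavy atoms and a hydrogen-bond acceptor. No measured evidence bears on this result. As far as these compounds go, whether an amine or a carboxylic acid on this aromatic carbon would shift the number beyond the scatter remains open, as does whether any group here gives a much lower number.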